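This account rests on a few compounds, and the source may have more. Where it says the series, first, only, none or still open, it means among the compounds named here.

Measured compounds in a functional assay on A549 cells (Homo sapiens) for cytotoxicity, read by MTT assay, with a stated time of 48 h; a higher number here means a weaker inhibitor, a lower number a stronger inhibitor:
- compound 1 `COc1cc(-c2nnc(SCC(=O)c3ccccc3C)n2N2C(=O)c3ccccc3C2=O)cc(OC)c1OC`: 144000 nM
- compound 2 `COc1cc(-c2nnc(SCC(=O)c3ccc(Br)cc3)n2N2C(=O)c3ccccc3C2=O)cc(OC)c1OC`: 16100 nM

Going by the values given here, compound 2 gives the lower of the two numbers in this assay; the one step measured, an 8.9-fold lower number from compound 1 to compound 2 (0.95 log units; beyond the scatter), separates it from compound 1 and lies beyond the scatter.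

Compound 3 `COc1cc(-c2nnc(SCC(=O)c3ccc(F)c(F)c3)n2N2C(=O)c3ccccc3C2=O)cc(OC)c1OC` is the next compound in the series, not yet measured. It differs from compound 2 only in 3,4-difluorophenyl in place of 4-bromophenyl on a carbonyl carbon. Among the compounds with values here, no measured step exchanges one halogenated phenyl for another, so the single measured step does not bear directly on this change; it only shows that the group on the carbonyl carbon can move the number in this assay well beyond the scatter. Without a closer precedent, the step of a 2.2-fold higher number from compound 2 to compound 3 (0.34 log units; beyond the scatter) is expected to be small, with a wide range in either direction. Compound 3 is therefore estimated at 35000 nM in this assay, within 9000 nM to 130000 nM.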

Compound 3, half-maximal inhibitory concentration: > 200000 nM
Compound 3: only a limit was reported; the forecaster's own chance of this, stated with the estimate: 15%; middle value at least 5.7-fold (0.75 log units) away from the limit.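

In this assay compound 3 gives a limit and not a number: the limit of > 200000 nM in this assay, at which 1 of the 3 values shown sits. On the carbonyl carbon, the exchange of 4-bromophenyl for 3,4-difluorophenyl is a large step, an at least 12-fold higher number from compound 2 to compound 3 (1.09 log units; beyond the scatter), so a halogen-bearing phenyl at this place does not by itself keep the result of compound 2. The other new step reads an at least 1.3-fold higher number from compound 1 to compound 3 (0.14 log units; that floor lies within the scatter), and these values do not set compound 3 apart from compound 1.

Still open, from the compounds shown here alone, is whether the large step follows the loss of bromine or the entry of the two fluorines; a 4-chlorophenyl or 4-fluorophenyl group would bear on this. Also open, going by these compounds, is whether a phenyl carrying no halogen, such as 4-methoxyphenyl or 4-aminophenyl, can give a lower number than compound 2.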